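Replacing propanoyl with methylsulfonyl at the assay limit

This account rests on a few compounds, and the source may have more. Where it says the series, first, only, none or still open, it means among the compounds named here.

In an ADME assay on microsomes from liver (Homo sapiens) for metabolic stability, read by LC-MS, using NADPH, with stated times of 10 min and 30 min (on this read-out higher numbers stand for fast clearance and lower numbers for slow clearance), compound 1 `CC(=O)N[C@@H]1CCCc2c1cncc2N1CCc2cc(Cl)ccc2C1=O` gives 4.3 mL/min/kg. Compound 2 `CCC(=O)N[C@@H]1CCCc2c1cncc2N1CCc2cc(Cl)ccc2C1=O` reports only a limit, < 3.5 mL/min/kg, so it has no exact position on the scale. Compound 3 `CC1(C)c2cc(Cl)ccc2C(=O)N1c1cccnc1` also reports only a limit, < 3.5 mL/min/kg. The values shown therefore crowd against (the limit of < 3.5 mL/min/kg in this assay, at which 2 of the 3 values shown sit).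

Compound 4 `CS(=O)(=O)N[C@@H]1CCCc2c1cncc2N1CCc2cc(Cl)ccc2C1=O` follows from compound 2 by methylsulfonyl in place of propanoyl on an amine nitrogen. Going by the values given here, the one measured step bearing on this group is an at least 1.2-fold lower number from compound 1 to compound 2 (0.08 log units; that floor lies within the scatter), and it retains the carbonyl, so methylsulfonyl itself remains untested. No change beyond the scatter is therefore expected in this assay, and no direction is favoured. The expected step is an at least 1.1-fold higher number from compound 2 to compound 4 (0.05 log units; that floor lies within the scatter). For compound 4, the estimated clearance is 4 mL/min/kg, with an expected range of 2.5 mL/min/kg to 8 mL/min/kg.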

Compound 4, clearance: < 3.5 mL/min/kg
Compound 4 ended at the assay's limit (the forecaster's own chance of this, stated with the estimate: 50%); at least 1.1-fold (0.05 log units) between middle value and limit.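

Methylsulfonyl on the amine nitrogen now has a reading in this assay: compound 4 reports only a limit, < 3.5 mL/min/kg. The acetyl to methylsulfonyl change gives an at least 1.2-fold lower number from compound 1 to compound 4 (0.08 log units; that floor lies within the scatter), while the propanoyl to methylsulfonyl step cannot be read, as both ends are limits. The carbonyl is therefore not needed at this position for a result at the limit, and the series crowds further against it: the limit of < 3.5 mL/min/kg in this assay, at which 3 of the 4 values shown sit.

From the compounds shown here alone, how compound 2 and compound 4 rank beyond the limit stays open. Also open, going by these compounds, is whether a free amine or a longer sulfonyl chain on this nitrogen would give a readable value.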